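An ester-to-ether swap on a quinone side chain

The compounds below may be only part of what the source reports. "The series", "measured", "known", "first", "only" and "open" are said of these compounds alone.

Two compounds share a quinone core that carries a side chain fixed through an oxygen. Compound 1 `CCCCC(O)CC(=O)O[C@H](CC=C(C)C)C1=CC(=O)c2c(O)ccc(O)c2C1=O` bears a (2-hydroxyhexyl)carbonyl group on that oxygen, and in a functional assay on DU-145 cells (Homo sapiens) for cytotoxicity, read by MTT assay (a higher number here means a weaker inhibitor, a lower number a stronger inhibitor), compound 1 gives 45300 nM. Compound 2 `CCCC(CC(=O)O[C@H](CC=C(C)C)C1=CC(=O)c2c(O)ccc(O)c2C1=O)OC(C)=O` differs only by 1-acetoxybutyl in place of 1-hydroxypentyl on a saturated chain carbon bound to a carbonyl carbon; in this assay compound 2 gives 55700 nM. The two values sit within the scatter of each other, so neither compound is set apart by these numbers.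

Compound 3 `CC(=O)OC(C)CO[C@H](CC=C(C)C)C1=CC(=O)c2c(O)ccc(O)c2C1=O` has not yet been measured. It differs from compound 1 as follows: 2-acetoxypropyl in place of (2-hydroxyhexyl)carbonyl on an oxygen on a saturated carbon. For the measured compounds named here, the only step on record, a 1.2-fold higher number from compound 1 to compound 2 (0.09 log units; within the scatter), also traded a hydroxyl for an acetoxy group at the side chain and produced no movement beyond the scatter. Going by the values given here, the shift to an ether link has no measured precedent here, so a modest change at most is expected, a 1.1-fold higher number from compound 1 to compound 3 (0.04 log units; within the scatter). Compound 3 is therefore estimated at 50000 nM, with a range from 20000 nM to 125000 nM.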

Compound 3, half-maximal inhibitory concentration: 16600 nM
For compound 3 the middle estimate is 3.0-fold (0.48 log units) above the measured one; measured number outside the range, below it.
By their numbers in this assay, from the lowest: compound 3; then compounds 1 and 2 (each within the scatter of the next).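

The group on this oxygen can shift the reading: in this assay, 2-acetoxypropyl in place of (2-hydroxyhexyl)carbonyl gives a 2.7-fold lower number from compound 1 to compound 3 (0.44 log units; beyond the scatter), whereas the values of the earlier pair stayed within the scatter of each other. This is a modest step, but it shows that the reading does not stay flat for every side-chain change on this core. No evidence here explains the shift.

The swap replaces the whole group at once, removing the carbonyl on the oxygen, exchanging the hydroxyl for an acetoxy group and shortening the chain, so the compounds shown cannot assign the step to any one of these parts. A 2-hydroxypropyl group on the same oxygen, or an amine in place of the acetoxy group, would help separate these parts.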